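The source may hold more compounds than are shown below. What is called first, only, known or untested is meant among the compounds shown, and "the series" means these compounds.

Compound 2, `CNC(=O)C1=CC(C)(C)Oc2ccc([N+](=O)[O-])cc21`, stands lowest of the two measured compounds in a functional assay on the whole organism (aorta) with Rattus norvegicus as the target (on this read-out lower numbers stand for smaller maximal responses and higher numbers for larger maximal responses), where compound 2 gives 61%. Its nearest neighbour among the measured compounds is compound 1, `C/N=C(/S)C1=CC(C)(CF)Oc2ccc([N+](=O)[O-])cc21`, which in this assay gives 77.1%, a number beyond the scatter above that of compound 2. Among the compounds with values here, the two differ in more than one place, so their values alone show only that compound 1 reaches the larger response.

Compound 3, `CNC(=O)C1=CC(C)(CF)Oc2ccc([N+](=O)[O-])cc21`, has not been measured in this assay. It differs from compound 2 by fluoro in place of hydrogen on a saturated chain carbon bound to a saturated ring carbon.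

Within the data shown here, since no measured pair isolates this change, the direction is read only from compound 1, which carries the fluoromethyl group and gives 77.1%. A modest upward step is expected from compound 2 to compound 3, a number 7 percentage points higher from compound 2 to compound 3 (within the scatter), possibly within the scatter. Compound 3 is therefore estimated at 68%, with a range from 52% to 84%.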

Compound 3, intrinsic activity: the largest response reached, in percent of the reference agonist's: 66%
Beside the measured number, compound 3's estimate is 2 percentage points above it; the measured number falls inside the stated range.
By their numbers in this assay, from the lowest: compounds 2 and 3 (each within the scatter of the next); then compound 1.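

In this assay, methyl to fluoromethyl on a saturated chain carbon bound to a saturated ring carbon gives a number 5 percentage points higher from compound 2 to compound 3 (within the scatter), so with the rest of the structure held fixed, this change does not separate the two compounds on this read-out. With the fluoromethyl group held fixed, replacing the sulfur-bearing group on the double-bonded ring carbon with the oxygen-bearing group gives a number 11.1 percentage points lower from compound 1 to compound 3 (beyond the scatter), which ties the larger response of compound 1 to that group rather than to the fluoromethyl group. No measurement among the data shown accounts for the size of either step.

On these data alone, whether trifluoromethyl or a longer chain such as ethyl at this place would also leave the response within the scatter remains open. Also open, as far as these compounds go, is whether the sulfur-bearing group keeps its larger response with methyl in place of fluoromethyl.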